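Swapping Ethoxy for Dimethylamino on the Shared Core

A few compounds are considered here, and "the series" means these few. Any claim that something is new, unique, unknown or untested is made for them only; others in the source may bear on it.

Compound 1 `Cc1cc(COc2cccc(F)c2)nc(-c2ccccn2)n1` gives 794 nM in a functional assay on cells for antagonist activity at Free fatty acid receptor 1 (Homo sapiens), read by TR-FRET and inositol phosphate accumulation, with a stated time of 2 h; a higher number here means a weaker inhibitor, a lower number a stronger inhibitor.
Compound 2 `COc1cc(COc2cccc(F)c2)nc(-c2ccccn2)n1` gives 1260 nM in this assay.
Compound 3 `CCOc1cc(COc2cccc(F)c2)nc(-c2ccccn2)n1` gives 251 nM in this assay.

Compound 3 holds the lowest of the three numbers. Its nearest neighbour is compound 1, reached by a 3.2-fold lower number from compound 1 to compound 3 (0.50 log units; beyond the scatter), and compound 2 lies furthest off, reached by a 5.0-fold lower number from compound 2 to compound 3 (0.70 log units; beyond the scatter). Compound 1 and compound 2 themselves differ only by a 1.6-fold higher number from compound 1 to compound 2 (0.20 log units; within the scatter).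

Compound 4 `CN(C)c1cc(COc2cccc(F)c2)nc(-c2ccccn2)n1` is the member still to be measured. It differs from compound 3 by dimethylamino in place of ethoxy on an aromatic carbon, a dimethylamino in place of ethoxy on the aromatic carbon next to the ring nitrogen. Both steps that lead into compound 3 concern this same carbon: replacing methyl or methoxy by ethoxy lowered the number in each case. Among the compounds with values here, no measured step exchanges an oxygen-linked group for a nitrogen-linked one at this position, so the direction of this change has no direct precedent. The entering and leaving groups match in heavy-atom count and in acceptor count.

Compound 4 is therefore expected to sit modestly above compound 3 in this assay, an expected step of a 2.0-fold higher number from compound 3 to compound 4 (0.30 log units; within the scatter). The estimate for compound 4 is 500 nM, with a range from 150 nM to 1800 nM.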

Compound 4, half-maximal inhibitory concentration: 1580 nM
Compound 4: the middle estimate sits 3.2-fold (0.50 log units) below what was measured; the range from low to high includes it.
By their numbers in this assay, from the lowest: compound 3; then compounds 1, 2 and 4 (each within the scatter of the next).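

At this carbon, a group can match ethoxy in heavy-atom count and acceptor count and still shift the result in this assay, since dimethylamino in its place gives a 6.3-fold higher number from compound 3 to compound 4 (0.80 log units; beyond the scatter). The dimethylamino member keeps none of the advantage seen with ethoxy and stands level with the methyl and methoxy members, at a 2.0-fold higher number from compound 1 to compound 4 (0.30 log units; within the scatter) and a 1.3-fold higher number from compound 2 to compound 4 (0.10 log units; within the scatter), both within the scatter, so that among these four groups only ethoxy separates from the rest. No measured property is available to account for this difference between ethoxy and dimethylamino.

The compounds shown leave open whether the advantage depends on the oxygen link, the ethyl chain or the two together, and ethylamino, which keeps the ethyl chain on a nitrogen, would help separate these. They also leave open how far the trend from methoxy to ethoxy extends along longer or branched oxygen-linked chains such as propoxy and isopropoxy, and whether a cyclic amine such as pyrrolidine or morpholine would behave like dimethylamino at this carbon.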